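Swapping an Iodophenyl Arm for an Indole Ring

This account rests on a few compounds, and the source may have more. Where it says the series, first, only, none or still open, it means among the compounds named here.

Compound 2 `O=C(/C(=C\c1ccc(I)cc1)Sc1ccc(Br)cc1)c1ccc(Br)cc1` was tested in a functional assay on DU-145 cells (Homo sapiens) for inhibition, read by trypan blue exclusion, with a stated time of 96 h (on this read-out lower numbers stand for stronger inhibition of growth and higher numbers for weaker inhibition of growth), where compound 2 gives 1000 nM. Where compound 2 carries iodo, compound 1 `O=C(/C(=C\c1ccc(Cl)cc1)Sc1ccc(Br)cc1)c1ccc(Br)cc1` carries chloro, and compound 1 gives 1000 nM in this assay, so compound 2 sits level with compound 1 on the numbers shown. That single step reads no change at the digits printed from compound 1 to compound 2 (within the scatter). Compound 3 `O=C(/C(=C\c1c[nH]c2ccccc12)Sc1ccc(Br)cc1)c1ccc(Br)cc1` has not yet been measured. It differs from compound 2 by 1H-indol-3-yl in place of 4-iodophenyl on a double-bonded chain carbon bound to a double-bonded chain carbon. Within the data shown here, the one measured step exchanges a halogen for another halogen on an aromatic carbon and left the read-out unchanged; it says little about exchanging a whole 4-iodophenyl for a 1H-indol-3-yl, a change of a different kind. Among the measured compounds shown here, with no closer precedent, the step is expected to be no change at the digits printed from compound 2 to compound 3 (within the scatter), no change beyond the scatter. Compound 3 is therefore estimated at 1000 nM in this assay, within a wide range from 300 nM to 5000 nM.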

Compound 3, concentration for 50% growth inhibition: 1000 nM
For compound 3 middle estimate and measured number coincide at the digits printed, within the range that was stated.
By their numbers in this assay, from the lowest: compounds 1, 2 and 3 (each within the scatter of the next).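

The earlier step exchanged only one halogen for another, whereas this change replaces a whole ring-bearing group, and this assay still shows no change at the digits printed from compound 2 to compound 3 (within the scatter) and no change at the digits printed from compound 1 to compound 3 (within the scatter). On a double-bonded chain carbon bound to a double-bonded chain carbon, then, 1H-indol-3-yl, with its five-membered ring and hydrogen-bond donor, can stand in for 4-iodophenyl or 4-chlorophenyl with no shift in growth inhibition beyond the scatter. No outside measurement is available to explain this outcome.

On these data alone, it remains open whether a group of a very different kind at this place, such as an amine, a carboxylic acid or a plain alkyl chain, would also leave growth inhibition unchanged. As far as these compounds go, the rest of the core is the same in all three compounds, so the effect of changes there also remains open.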